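The source may report more compounds than this note shows. Statements on the series, on what has been measured and on what is new or still open speak of the compounds shown alone.

Within the data shown here, compound 3 `O=C(NO)c1ccc(/C=C/c2ccnc(-c3cccc(CO)c3)c2)cc1` is the most potent of the three compounds measured so far. In an assay on isolated protein for inhibition of protein deacetylase HDAC6 (Homo sapiens), read by fluorescence, with a stated time of 15 min (on this read-out higher numbers stand for weaker inhibition and lower numbers for stronger inhibition), compound 3 gives 34 nM, and its distance to both other compounds lies beyond the usual scatter. Among the measured compounds shown here, compound 1 `O=C(NO)c1cccc(/C=C/c2ccnc(-c3cc(F)ccc3O)c2)c1` gives 400 nM in this assay, and compound 2 `O=C(NO)c1cccc(/C=C/c2ccnc(-c3ccccc3O)c2)c1` gives 390 nM, the two values being indistinguishable; the one measured step, a 1.0-fold lower number from compound 1 to compound 2 (0.01 log units; within the scatter), shows that a fluoro on an aromatic carbon made no difference there.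

Compound 4 `Cc1ccc(-c2cc(/C=C/c3ccc(C(=O)NO)cc3)ccn2)c(F)c1` differs from compound 3 in one place: 2-fluoro-4-methylphenyl in place of 3-(hydroxymethyl)phenyl on an aromatic carbon. For the measured compounds named here, no measured step covers the loss of the hydroxymethyl and its donor and acceptor; only the fluoro exchange between compound 1 and compound 2 bears on the change, and that step was within the scatter. Compound 4 is therefore expected to be somewhat weaker than compound 3, by a step of a 2.4-fold higher number from compound 3 to compound 4 (0.37 log units; beyond the scatter), with wide uncertainty. The estimate for compound 4 in this assay is 80 nM, in the range 25 nM to 250 nM.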

Compound 4, half-maximal inhibitory concentration: 15 nM
Compound 4: the middle estimate sits 5.3-fold (0.73 log units) above what was measured; the whole stated range lies above it.
By their numbers in this assay, from the lowest: compound 4; then compound 3; then compounds 2 and 1 (each within the scatter of the next).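

In this assay, the group on the aromatic carbon next to the ring nitrogen can lose its hydroxymethyl without any loss of inhibition: 2-fluoro-4-methylphenyl in place of 3-(hydroxymethyl)phenyl gives a 2.3-fold lower number from compound 3 to compound 4 (0.36 log units; beyond the scatter). The aryl group at this position therefore needs no hydrogen-bond donor or acceptor for a low number, and a change here can move the number beyond the scatter, which the fluoro exchange between compound 1 and compound 2 did not do. Nothing available explains this step.

From the compounds shown here alone, the hydroxymethyl leaves and the fluoro and methyl enter in a single change, so which of them carries the step stays open. Also open, going by these compounds, is how an aminomethyl or a carboxylic acid on this phenyl ring would read in this assay.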